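Bromo on the pyridin-2-yl amide: expected step

The source may report more compounds than this note shows. Statements on the series, on what has been measured and on what is new or still open speak of the compounds shown alone.

In a functional assay on KB cells (Homo sapiens) for inhibition, read by MTT assay, with a stated time of 24 h, tested at 10 ug/mL (on this read-out higher numbers stand for more inhibition of growth at the one concentration tested and lower numbers for less inhibition of growth), compound 1 (`O=C(CCCCC(S)CCS)NO`), with hydroxy on the amide nitrogen, gives 41.5% of inhibition. Compound 2 (`O=C(CCCCC(S)CCS)Nc1ccccc1`), with phenyl there, gives 8.62% at the same concentration, and compound 3 (`O=C(CCCCC(S)CCS)Nc1ccccn1`), with pyridin-2-yl, gives 0.28% in the same test. Compound 3 thus sits at the low end of the three numbers, within the scatter of compound 2 and well away from compound 1.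

The two steps away from hydroxy are large: a number 32.9 percentage points lower from compound 1 to compound 2 (beyond the scatter) and a number 41.2 percentage points lower from compound 1 to compound 3 (beyond the scatter) on this read-out. Within the data shown here, the only step between aromatic groups is small: a number 8.3 percentage points lower from compound 2 to compound 3 (within the scatter) and so gives no real separation.

Compound 4 (`O=C(CCCCC(S)CCS)Nc1ccc(Br)cn1`) differs from compound 3 by one change (bromo in place of hydrogen on an aromatic carbon), bromo in place of hydrogen on an aromatic carbon, two atoms from the ring nitrogen and para to a large group. Among the measured compounds shown here, no measured compound carries a substituent on its aromatic ring, so no step speaks directly to bromo. The nearest guide is the small step between the aromatic groups, while the two large steps concern hydroxy, which compound 4 lacks.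

In this assay the expected step is a number 6.7 percentage points higher from compound 3 to compound 4 (within the scatter) and it is expected to stay within the scatter. Compound 4 is estimated at 7% (expected range 0% to 20%).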

Compound 4, percent growth inhibition at one concentration: 34.1%
Beside the measured number, compound 4's estimate is 27.1 percentage points below it; measured number above the stated range.
By their numbers in this assay, from the lowest: compounds 3 and 2 (each within the scatter of the next); then compounds 4 and 1 (each within the scatter of the next).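

In this assay, one bromo on an aromatic carbon, two atoms from the ring nitrogen and para to a large group, gives a step as large as those seen so far only on leaving hydroxy: a number 33.8 percentage points higher from compound 3 to compound 4 (beyond the scatter). The aromatic amides are therefore not uniformly low, since compound 4 at 34.1% lies within the scatter of compound 1 at 41.5%, so among these compounds hydroxy on the amide nitrogen is not the only route to a number at that level. No measurement at hand explains this step.

On these data alone, it remains open whether the step is particular to bromo or would also appear with chloro, methyl or an amine at the same place, and whether bromo on another carbon of the ring would give a similar number. Also open, as far as these compounds go, is whether bromo on the phenyl ring of compound 2 would produce a step of this size, and a read-out at one concentration says nothing about how the inhibition changes with dose.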